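Methoxy in Place of Methyl: A Small Step Expected

The source may report more compounds than this note shows. Statements on the series, on what has been measured and on what is new or still open speak of the compounds shown alone.

Compound 3 `Cc1ccc2nc(C(=O)Nc3c(F)cc(-c4cccc(F)c4)cc3F)c(C)c(C(=O)O)c2c1` stands lowest of the three numbers in a functional assay on A-375 cells (Homo sapiens) for antiproliferative activity, read by MTT assay, with a stated time of 24 h, tested at 0.14 ug/mL (a higher number here means a stronger effect of the compound at the concentration tested, a lower number a weaker effect), where compound 3 gives 0.98%. Its nearest neighbour is compound 1 `Cc1ccc2nc(C(=O)Nc3c(F)cc(-c4cccc(F)c4)cc3F)c(C)c(O)c2c1`, which in this assay gives 1.06%; the step of a number 0.1 percentage points lower from compound 1 to compound 3 (within the scatter) came with carboxy in place of hydroxy on an aromatic carbon. Furthest away is compound 2 `Cc1c(C(=O)Nc2c(F)cc(-c3cccc(F)c3)cc2F)nc2ccc(C(F)(F)F)cc2c1O`, which in this assay gives 9.37%; the step of a number 8.3 percentage points higher from compound 1 to compound 2 (within the scatter) came with trifluoromethyl in place of methyl on an aromatic carbon. All three numbers therefore lie within the scatter of one another, and none can be called stronger or weaker than the others.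

Compound 4 `COc1ccc2nc(C(=O)Nc3c(F)cc(-c4cccc(F)c4)cc3F)c(C)c(C(=O)O)c2c1` has not yet been measured. It differs from compound 3 in one place: methoxy in place of methyl on an aromatic carbon. Within the data shown here, no measured step exchanges methyl for methoxy. Among the measured compounds shown here, the only measured step that also replaces a methyl on an aromatic carbon is a number 8.3 percentage points higher from compound 1 to compound 2 (within the scatter), and it stayed within the scatter, as did a number 0.1 percentage points lower from compound 1 to compound 3 (within the scatter). On that basis the step in this assay is expected to be a number 2 percentage points higher from compound 3 to compound 4 (within the scatter), with no change beyond the scatter. Compound 4 is therefore estimated at 3%, with a range from 0% to 12%.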

Compound 4, a percentage reported as inhibition, at one concentration (the size of the read-out at that concentration, not a potency): 2.06%
For compound 4 the middle estimate is 0.9 percentage points above the measured one; the range from low to high includes it.
By their numbers in this assay, from the lowest: compounds 3, 1, 4 and 2 (each within the scatter of the next).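

In this assay, the exchange of methyl for methoxy on the aromatic carbon meta to a fused ring and para to a fused ring gave a number 1.1 percentage points higher from compound 3 to compound 4 (within the scatter), which shows that the oxygen and the hydrogen-bond acceptor that methoxy brings do not separate the two compounds in this read-out. Among these compounds, this carbon had so far been probed only by trifluoromethyl, on the hydroxy-bearing core, with a number 8.3 percentage points higher from compound 1 to compound 2 (within the scatter); the new step adds a second replacement of methyl there, now on the carboxy-bearing core, and both replacements stay within the scatter. Nothing in the data at hand explains the result or links it to any property of the group.

The compounds shown leave open whether an amine, a chlorine atom or a longer chain such as ethoxy on this carbon would give a step beyond the scatter, and whether methoxy would behave the same way on the core that carries hydroxy instead of carboxy. Since every number comes from a single concentration, they also leave open how these compounds would compare at higher concentrations.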